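A few compounds are considered here, and "the series" means these few. Any claim that something is new, unique, unknown or untested is made for them only; others in the source may bear on it.

Three compounds share one core, each carrying a pyrrolidin-3-yl group on an aromatic nitrogen and a sulfonyl group whose far side varies. In a functional assay on HeLa cells for agonist activity at 5-hydroxytryptamine receptor 6 (Homo sapiens), read by cAMP accumulation and immunoassay (a lower number here means that less compound is needed, a higher number that more compound is needed for the effect), compound 1 `O=S(=O)(c1cccc(Br)c1)c1cn(C2CCNC2)c2ncccc12` gives 35 nM. Compound 2 `O=S(=O)(c1cccc(C(F)(F)F)c1)c1cn(C2CCNC2)c2ncccc12` gives 520 nM in this assay. Compound 3 `O=S(=O)(C1=C(Cl)NC2SC=CN12)c1cn(C2CCNC2)c2ncccc12` gives 80 nM in this assay, which places it second highest of the three: compound 1 stands at a lower number, compound 2 at a higher one. Within the data shown here, the single measured step that changes one place, a 15-fold higher number from compound 1 to compound 2 (1.17 log units; beyond the scatter), is a large one, but it concerns a trifluoromethyl in place of bromo on an aromatic carbon and leaves the pyrrolidin-3-yl group untouched. Compound 4 `O=S(=O)(C1=C(Cl)NC2SC=CN12)c1cn(C2CCCNC2)c2ncccc12` differs from compound 3 at that group instead: piperidin-3-yl in place of pyrrolidin-3-yl on an aromatic nitrogen. Among the measured compounds shown here, no measured step alters this ring, so that step gives no direct guide, and the change keeps the donor and acceptor while enlarging the ring. A step of modest size is therefore expected, a 1.5-fold higher number from compound 3 to compound 4 (0.18 log units; within the scatter), likely within the scatter. Compound 4 is expected to give about 120 nM, with a range from 40 nM to 400 nM.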

Compound 4, half-maximal effective concentration: 66 nM
The estimate for compound 4 lay 1.8-fold (0.26 log units) above the measured number, and the stated range covers the measured number.
By their numbers in this assay, from the lowest: compounds 1, 4 and 3 (each within the scatter of the next, the first and the last beyond it); then compound 2.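

Putting piperidin-3-yl in place of pyrrolidin-3-yl on the aromatic nitrogen gives a 1.2-fold lower number from compound 3 to compound 4 (0.08 log units; within the scatter) in this assay and leaves the two compounds indistinguishable. Among these compounds, the earlier step changed only the far side of the sulfonyl group, so this is the first measured change at this position, and it shows that, with the far side of compound 3 held fixed, the six-membered ring serves as well as the five-membered one. Nothing available explains why the ring size makes so little difference here.

From the compounds shown here alone, it remains open whether the same swap would be as quiet with the far side of compound 1. An azetidin-3-yl ring, an open aminoethyl chain or a methyl group on the ring nitrogen would show how much change this position accepts.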